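Swapping a halogenated phenyl on the piperazine ring

The source may hold more compounds than are shown below. What is called first, only, known or untested is meant among the compounds shown, and "the series" means these compounds.

Compound 1, with structure `CCCn1c(=O)[nH]c2nc(-c3ccc(S(=O)(=O)N4CCN(c5ccccc5Br)CC4)cc3)[nH]c2c1=O`, was tested in an assay on CHO cells for displacement of a labelled ligand from adenosine receptor A3 (Homo sapiens), read by scintillation counting, with a stated time of 45 min, in the presence of a further agent that is not named here; on this read-out lower numbers stand for stronger inhibition and higher numbers for weaker inhibition. In this assay compound 1 gives > 1000 nM, which is a limit of the assay rather than a measured number. Compound 2, with structure `CCCn1c(=O)c2[nH]c(-c3ccc(S(=O)(=O)N4CCN(c5ccc(Cl)cc5)CC4)cc3)nc2n(C)c1=O`, gives > 1000 nM in this assay, again a limit. Compound 3, with structure `CCCn1c(=O)[nH]c2nc(-c3ccc(S(=O)(=O)N4CCN(c5ccccc5)C(C)C4)cc3)[nH]c2c1=O`, gives > 1000 nM in this assay, also a limit. Every value shown so far therefore sits at the limit of > 1000 nM in this assay, at which 3 of the 3 values shown sit, so compound 1 stands with the others at the weak end and cannot be placed among them by order.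

Compound 4, with structure `CCCn1c(=O)[nH]c2nc(-c3ccc(S(=O)(=O)N4CCN(c5ccc(F)cc5)CC4)cc3)[nH]c2c1=O`, has not yet been measured. It differs from compound 1 in one place: 4-fluorophenyl in place of 2-bromophenyl on an amine nitrogen in a ring. Among the measured compounds shown here, no step between measured compounds exists to show what such a change does, and the three compounds, each with a different group on the ring amine nitrogen, all remain at the limit. The expected step that the limit leaves unreadable from compound 1 to compound 4 is therefore none beyond the scatter. Compound 4 is estimated at 2500 nM, within 600 nM to 12000 nM.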

Compound 4, inhibition constant: > 1000 nM
Compound 4 was reported as a limit; the forecaster's own chance of this, stated with the estimate: 70%; the middle value lies beyond the limit too.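

In this assay, among the compounds shown here, compound 4 gives > 1000 nM and this is a limit, as is the result for compound 1, so no step from compound 1 to compound 4 can be read. All the results shown stand together: the limit of > 1000 nM in this assay, at which 4 of the 4 values shown sit. The compounds shown leave open how strongly any of them binds, and which group on the ring amine nitrogen, if any, would give a measurable value.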